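Diethylamino for pyrrolidin-1-yl: notes on the side chain

A few compounds are considered here, and "the series" means these few. Any claim that something is new, unique, unknown or untested is made for them only; others in the source may bear on it.

In a functional assay on MGC-803 cells (Homo sapiens) for inhibition (a lower number here means a stronger inhibitor, a higher number a weaker inhibitor), compound 3 (`O=C(CC(CC(=O)NC1Cc2ccccc2C1)c1ccccc1)NCCN1CCCC1`) gives > 100000 nM as a limit, not a number. Compound 2 (`O=C(CC(CC(=O)NC1Cc2ccccc2C1)c1ccccc1)NCCN1CCCCC1`) gives > 100000 nM as a limit. Within the data shown here, the series so far shows the limit of > 100000 nM in this assay, at which 3 of the 3 values shown sit, and no measured number. Among the measured compounds shown here, the one measured step is a step that the two limits leave unreadable from compound 2 to compound 3 and offers no size to carry over.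

The change to compound 4 (`CCN(CC)CCNC(=O)CC(CC(=O)NC1Cc2ccccc2C1)c1ccccc1`) is diethylamino in place of pyrrolidin-1-yl on a saturated chain carbon, two bonds along the chain from an amide-type nitrogen with diethylamino in place of pyrrolidin-1-yl on a saturated chain carbon, two bonds along the chain from an amide-type nitrogen. Compound 1 (`CCN(CC)CCNC(=O)CC(CC(=O)NC1Cc2ccccc2C1)c1ccc(Cl)cc1`) also carries diethylamino and gives > 100000 nM as a limit.

In this assay the expected move is a number no higher from compound 3 to compound 4 (the limit leaves the size open) with no shift beyond the scatter expected. For compound 4 the estimate is 100000 nM with an expected range from 40000 nM to 200000 nM and a limit is the likeliest report.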

Compound 4, half-maximal inhibitory concentration: > 100000 nM
Compound 4: a limit, no number (the forecaster's own chance of this, stated with the estimate: 80%); the middle value lies on the limit itself.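

In this assay no step can be read from compound 4 to compound 1, compound 2 or compound 3, since all four stand at a limit: the limit of > 100000 nM in this assay, at which 4 of the 4 values shown sit.

As far as these compounds go, whether the side-chain amine, or chloro against hydrogen, changes inhibition in this assay at all remains open.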